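Working notes: aryl exchange from compound 2 to compound 3

A few compounds are considered here, and "the series" means these few. Any claim that something is new, unique, unknown or untested is made for them only; others in the source may bear on it.

Two members of this series have been run in an assay on CHO cells for displacement of a labelled ligand from adenosine receptor A1 (Homo sapiens), read by scintillation counting, tested at 10 uM; on this read-out lower numbers stand for less inhibition and higher numbers for more inhibition at the one concentration tested (going by the name of the read-out). Compound 1 `COc1ccc(-c2sc(N)c(C(=O)c3ccc(Cl)cc3)c2C)cc1` gives 1% in this assay. Compound 2 `CC(C)(C)Cc1c(-c2cccc(F)c2F)sc(N)c1C(=O)c1ccc(Cl)cc1` gives 1% in this assay, which is level with compound 1 at the digits shown; the two values lie within the scatter of each other, so no order between them can be read. Among the measured compounds shown here, both sit at the bottom of the read-out, and no step between measured compounds is available to show how any change on the shared core moves the number.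

Compound 3 `CC(C)(C)Cc1c(-c2ccco2)sc(N)c1C(=O)c1ccc(Cl)cc1` has not yet been measured. It differs from compound 2 in one place: furan-2-yl in place of 2,3-difluorophenyl on an aromatic carbon.

With compound 1 and compound 2 both giving values close to zero, no direction is indicated. The expected step of a number 2 percentage points higher from compound 2 to compound 3 (within the scatter) is none beyond the scatter, since compound 2 gives 1% and compound 1 gives 1%. Compound 3 is therefore estimated at 3% in this assay, within a range of 0% to 14%.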

Compound 3, a percentage reported as inhibition, at one concentration (the size of the read-out at that concentration, not a potency): 1%
Estimate against measurement, compound 3: 2 percentage points above; measured number inside the range.
By their numbers in this assay, from the lowest: compounds 1, 2 and 3 (each within the scatter of the next).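

Placing furan-2-yl in place of 2,3-difluorophenyl on the aromatic carbon next to the ring sulfur, with the neopentyl group and the (4-chlorophenyl)carbonyl group kept, gives in this assay the first step that can be read in this series: no change at the digits printed from compound 2 to compound 3 (within the scatter). At this position, then, a five-membered aromatic ring with an oxygen as hetero atom reads the same as a fluorinated six-membered aromatic ring of carbon only, and with compound 3 at 1% the number stays at the bottom of the read-out, so the step gives no direction for further work at this position. No measured evidence offers an explanation for this result.

With all values at the bottom of the read-out, the compounds shown leave open whether anything on this aromatic carbon can move the number. A dimethylaminomethyl group or a carboxylic acid at this position, or a free carboxylic acid or an acetyl group in place of the amino group on the shared core, would test that.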